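Fusing a Saturated Ring onto the Thiazole of Compound 2

The compounds below may be only part of what the source reports. "The series", "measured", "known", "first", "only" and "open" are said of these compounds alone.

Compound 1 `CC(C)(O)c1ccccc1CC[C@@H](SCC1(CC(=O)O)CC1)c1cccc(/C=C/c2nccs2)c1`: 381 nM
Compound 2 `CC(C)c1csc(/C=C/c2cccc([C@@H](CCc3ccccc3C(C)(C)O)SCC3(CC(=O)O)CC3)c2)n1`: 1.9 nM
Compound 3 `Cc1sc(/C=C/c2cccc([C@@H](CCc3ccccc3C(C)(C)O)SCC3(CC(=O)O)CC3)c2)nc1C(C)C`: 12.8 nM; 5.2 nM (2 entries)

In an assay on membranes from lung for inhibition of cysteinyl leukotriene receptor 1 (Cavia porcellus) (a lower number here means a stronger inhibitor, a higher number a weaker inhibitor), compound 2 holds the lowest of the two single numbers; compound 3 has several entries rather than one number, shown in the several entries of compound 3 in this assay, 12.8 nM; 5.2 nM (2 entries). Compound 4 `CC(C)(O)c1ccccc1CC[C@@H](SCC1(CC(=O)O)CC1)c1cccc(/C=C/c2nc3c(s2)CCCC3)c1` differs from compound 2 by a group of 9 heavy atoms (7 carbon, 1 nitrogen, 1 sulfur; one five-membered aromatic ring with 2 hetero atoms, one six-membered non-aromatic ring of carbon only) in place of a group of 8 heavy atoms (6 carbon, 1 nitrogen, 1 sulfur; one five-membered aromatic ring with 2 hetero atoms), on a double-bonded chain carbon bound to a double-bonded chain carbon. Within the data shown here, the one measured step that bears on this position is a 200-fold lower number from compound 1 to compound 2 (2.30 log units; beyond the scatter), showing that substitution on the thiazole matters greatly. Compound 3, carrying a methyl as well as the isopropyl on that ring, stays close to compound 2. A new ring in place of the isopropyl is therefore expected to keep compound 4 near compound 2, with a step of a 3.2-fold higher number from compound 2 to compound 4 (0.50 log units; beyond the scatter). Compound 4 is estimated at 6 nM, in the range 1.5 nM to 25 nM.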

Compound 4, half-maximal inhibitory concentration: 1.5 nM
Beside the measured number, compound 4's estimate is 4.0-fold (0.60 log units) above it, and the stated range covers the measured number.
By their numbers in this assay, from the lowest: compounds 4 and 2 (each within the scatter of the next); then compound 1.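

In this assay, the step from the isopropyl group to the fused six-membered carbon ring is a 1.3-fold lower number from compound 2 to compound 4 (0.10 log units; within the scatter), so the open branched chain can be tied back into a ring with no measurable change. The ring also gives a 250-fold lower number from compound 1 to compound 4 (2.40 log units; beyond the scatter), so a large step at this position does not depend on the isopropyl group itself. Nothing measured here explains this tolerance.

Still open, from the compounds shown here alone, is how a fused ring carrying an amine, or a fused seven-membered carbon ring, would behave at this position.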